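From compound 3 to compound 4: a benzyl exchange

The compounds below may be only part of what the source reports. "The series", "measured", "known", "first", "only" and "open" are said of these compounds alone.

Compound 1 `Cc1nc(C)c([C@H](OC(C)(C)C)C(=O)O)c(N2CCC(C)(C)CC2)c1-c1cnn(CCCc2ccc(F)cc2)c1`: >= 22000 nM (a limit)
Compound 2 `Cc1nc(C)c([C@H](OC(C)(C)C)C(=O)O)c(N2CCC(C)(C)CC2)c1-c1cnc(OCCc2ccc(F)cc2)nc1`: >= 22000 nM (a limit)
Compound 3 `Cc1cccc(Cl)c1CN1CCc2cc(-c3c(C)nc(C)c([C@H](OC(C)(C)C)C(=O)O)c3N3CCC(C)(C)CC3)ccc2C1`: 22500 nM

These three compounds were tested in a toxicity assay on MT2 cells (Homo sapiens) for cytotoxicity; a higher number here means that more compound is tolerated, a lower number that less compound is tolerated. Going by the values given here, compound 3 is the only one with an actual number, 22500 nM. The other two results are limits of the assay and not numbers: the limit of >= 22000 nM in this assay, at which 2 of the 3 values shown sit. Compound 3 therefore has no exact value to be set against, and the three results lie together.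

Compound 4 `Cc1nc(C)c([C@H](OC(C)(C)C)C(=O)O)c(N2CCC(C)(C)CC2)c1-c1ccc2c(c1)CCN(Cc1cccc(F)c1F)C2` keeps the shared core of compound 3 and carries 2,3-difluorophenyl in place of 2-chloro-6-methylphenyl, on a saturated chain carbon bound to an amine nitrogen in a ring: 2,3-difluorophenyl in place of 2-chloro-6-methylphenyl on a saturated chain carbon bound to an amine nitrogen in a ring. Put another way, 2-chloro-6-methylbenzyl becomes 2,3-difluorobenzyl. Among the compounds with values here, no measured pair of compounds isolates this change, so the expectation rests on the general level of the series. Compounds 1, 2 and 3 carry different groups on the shared core, and compound 3 still gives 22500 nM. No step beyond the scatter is therefore expected in this assay, in either direction. The expected step, a 1.0-fold lower number from compound 3 to compound 4 (0.01 log units; within the scatter), is small, and the result may again be only a limit. The estimated value for compound 4 is 22000 nM, with an expected range from 11000 nM to 35000 nM.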

Compound 4, half-maximal cytotoxic concentration: >= 24000 nM
Compound 4: only a limit was reported; the forecaster's own chance of this, stated with the estimate: 50%; middle value at least 1.0-fold (0.03 log units) from the limit.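

In this assay compound 4 gives >= 24000 nM, which is a limit of the assay and not a number: the limit of >= 24000 nM in this assay, at which 1 of the 4 values shown sits. Going by these compounds alone, the one-place comparison reads an at least 1.0-fold higher number from compound 3 to compound 4 (0.02 log units; that floor lies within the scatter), and it is the first in this set to isolate a change at this position, 2-chloro-6-methylbenzyl becoming 2,3-difluorobenzyl on a saturated chain carbon bound to an amine nitrogen in a ring. It shows that the chlorine and methyl of the leaving group can give way to two fluorines without a lower number appearing in this assay, although the true size of the step cannot be read from a limit.

The compounds shown leave open whether any group at this place would lower the number, for example a phenyl carrying an amine or a carboxylic acid, or a longer chain in place of the single benzyl carbon. On these data alone, the results for compound 1, compound 2 and compound 4 are all limits, so how much of each compound the cells tolerate before the half-maximal cytotoxic concentration is reached remains unknown for these three.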